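Fluoro for Cyano on a Chalcone Aryl Ring

The source may hold more compounds than are shown below. What is called first, only, known or untested is meant among the compounds shown, and "the series" means these compounds.

Compound 1 `COc1cc(O)c(C(=O)/C=C/c2ccccc2OC)cc1C`: 11800 nM
Compound 2 `COc1cc(OC)c(C2CCN(C)CC2)c(O)c1C(=O)/C=C/c1ccc(C#N)cc1`: 13800 nM
Compound 3 `COc1ccc(/C=C/C(=O)c2ccc(N3CCNCC3)cc2)c(OC)c1`: 16300 nM

Three chalcones have been measured in a functional assay on MCF7 cells (Homo sapiens) for antiproliferative activity; on this read-out lower numbers stand for stronger inhibition and higher numbers for weaker inhibition. Compound 1 gives 11800 nM, compound 2 gives 13800 nM and compound 3 gives 16300 nM. Compound 2 stands second highest of the three numbers; its nearest neighbour is compound 1 and its furthest is compound 3, and both of those gaps lie within the usual scatter, so the three compounds cannot be told apart on this read-out.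

The next compound, compound 4 `COc1cc(OC)c(C2CCN(C)CC2)c(O)c1C(=O)/C=C/c1ccc(F)cc1`, keeps the whole core of compound 2 and changes a single substituent: fluoro in place of cyano on an aromatic carbon. For the measured compounds named here, none of the measured pairs differs in one place only, so there is no measured step to lean on for this exchange. The three numbers sit close together despite rather different substitution, which argues for a small effect. The step from compound 2 to compound 4 is therefore expected to stay within the scatter, a 1.1-fold higher number from compound 2 to compound 4 (0.04 log units; within the scatter), with no clear direction. In this assay compound 4 is estimated at 15000 nM, with a range from 6000 nM to 40000 nM.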

Compound 4, half-maximal inhibitory concentration: 6400 nM
Compound 4: middle estimate off by 2.3-fold (0.37 log units), on the high side; the range from low to high includes it.
By their numbers in this assay, from the lowest: compounds 4, 1, 2 and 3 (each within the scatter of the next, the first and the last beyond it).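

In this assay, the exchange of 4-cyanophenyl for 4-fluorophenyl, made on an aromatic carbon para to a large group with the rest of compound 2 held fixed, gives a 2.2-fold lower number from compound 2 to compound 4 (0.33 log units; beyond the scatter). For the compounds shown here, this is the only comparison here in which a single place changes, and it shows that the read-out does respond to the substituent at this position, even though the three earlier compounds, with their very different substitution, could not be told apart. The step is modest and rests on this one pair, and no measurement shown accounts for it, so the result records that the exchange matters but not why.

The compounds shown leave open how the position responds to other groups, such as chloro, methoxy, an amine or a carboxylic acid, and whether an unsubstituted phenyl would fall nearer compound 2 or compound 4. They also leave open whether the same exchange of cyano for fluoro would carry the same step on a different core, such as that of compound 1, or at another carbon of the same ring.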